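Removing the Ethoxycarbonyl From the Ring Double Bond

The compounds below may be only part of what the source reports. "The series", "measured", "known", "first", "only" and "open" are said of these compounds alone.

Compound 1 `CCOCC1=Cc2ccc(OC)cc2OC1c1cc(OC)c(OC)c(OC)c1`: 21300 nM
Compound 2 `CCOC(=O)C1=Cc2ccc(OC)cc2OC1c1cc(OC)c(OC)c(OC)c1`: 25000 nM

In a functional assay for inhibition of nuclear factor NF-kappa-B complex (Homo sapiens) (on this read-out higher numbers stand for weaker inhibition and lower numbers for stronger inhibition), the two measured compounds sit side by side: the step of a 1.2-fold higher number from compound 1 to compound 2 (0.07 log units; within the scatter) lies within the scatter, so compound 2 is not set apart from compound 1 on these numbers. Compound 3 `COc1ccc2c(c1)OC(c1cc(OC)c(OC)c(OC)c1)C=C2` differs from compound 2 by hydrogen in place of ethoxycarbonyl on a double-bonded ring carbon. Going by the values given here, the only measured step bearing on this position, a 1.2-fold higher number from compound 1 to compound 2 (0.07 log units; within the scatter), exchanged one group for another there without a change beyond the scatter; no measured step removes the group outright. The expected step is therefore no change at the digits printed from compound 2 to compound 3 (within the scatter), within the scatter. Compound 3 is estimated at 25000 nM, with a range from 8000 nM to 80000 nM.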

Compound 3, half-maximal inhibitory concentration: 17700 nM
For compound 3 the middle estimate is 1.4-fold (0.15 log units) above the measured one; low and high end bracket the measured number.
By their numbers in this assay, from the lowest: compounds 3, 1 and 2 (each within the scatter of the next).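

Going by these compounds alone, with the group taken away entirely, this ring carbon bears only hydrogen for the first time, and in this assay the result is a 1.4-fold lower number from compound 2 to compound 3 (0.15 log units; within the scatter) and a 1.2-fold lower number from compound 1 to compound 3 (0.08 log units; within the scatter). Neither ethoxycarbonyl nor ethoxymethyl is therefore set apart from plain hydrogen at this position on these numbers. No evidence on the reason for this is available. As far as these compounds go, whether an amine, a carboxylic acid or a longer chain on this ring carbon would shift the number beyond the scatter remains open.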